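Removing the 2,6-dimethyl pattern: compound 4 from compound 2

This account rests on a few compounds, and the source may have more. Where it says the series, first, only, none or still open, it means among the compounds named here.

Of the compounds shown here, three from this series have been tested in a functional assay on Molt4/C8 cells (Homo sapiens) for cytotoxicity; on this read-out lower numbers stand for stronger inhibition and higher numbers for weaker inhibition. Compound 1 `Cc1ccc(NC(=O)/C=C/C(=O)N2C/C(=C\c3ccc([N+](=O)[O-])cc3)C(=O)/C(=C/c3ccc([N+](=O)[O-])cc3)C2)cc1C` gives 660 nM, compound 2 `Cc1cccc(C)c1NC(=O)/C=C/C(=O)N1C/C(=C\c2ccc([N+](=O)[O-])cc2)C(=O)/C(=C/c2ccc([N+](=O)[O-])cc2)C1` gives 210 nM, and compound 3 `Cc1ccc(NC(=O)/C=C/C(=O)N2C/C(=C\c3ccccc3)C(=O)/C(=C/c3ccccc3)C2)cc1` gives 660 nM. Compound 2 therefore holds the lowest of the three numbers, and both of the others stand at the same higher value. Within the data shown here, the only single-point step among the measured compounds is a 3.1-fold lower number from compound 1 to compound 2 (0.50 log units; beyond the scatter), showing that the shift to the 2,6-dimethylphenyl group lowered the number beyond the usual scatter.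

Compound 4 `Cc1ccc(NC(=O)/C=C/C(=O)N2C/C(=C\c3ccc([N+](=O)[O-])cc3)C(=O)/C(=C/c3ccc([N+](=O)[O-])cc3)C2)cc1` has not yet been measured in this assay. Relative to compound 2 the change is 4-methylphenyl in place of 2,6-dimethylphenyl on an amide-type nitrogen. This change undoes the 2,6-dimethylphenyl group that accompanied the lower number in compound 2, and it introduces the 4-methylphenyl group that compound 3 also carries, where compound 3 gives 660 nM. On this basis compound 4 is expected to move to a higher number than compound 2, by roughly the size seen in the reverse direction for compound 1 and compound 2, so that the expected step is a 2.6-fold higher number from compound 2 to compound 4 (0.42 log units; beyond the scatter). The estimate for compound 4 in this assay is therefore 550 nM, with a range from 250 nM to 1300 nM.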

Compound 4, half-maximal inhibitory concentration: 700 nM
Compound 4: middle estimate off by 1.3-fold (0.10 log units), on the low side; the measured number falls inside the stated range.
By their numbers in this assay, from the lowest: compound 2; then compounds 1, 3 and 4 (each within the scatter of the next).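

In this assay, the 4-methylphenyl group on the amide-type nitrogen gives a 3.3-fold higher number from compound 2 to compound 4 (0.52 log units; beyond the scatter) on the shared core, so a second group now differs from 2,6-dimethylphenyl, in addition to the 3,4-dimethylphenyl group of compound 1. The new pair also tests the extra methyl group of 3,4-dimethylphenyl: hydrogen in place of that methyl on an aromatic carbon gives a 1.1-fold higher number from compound 1 to compound 4 (0.03 log units; within the scatter) and leaves the two compounds within the scatter of each other. Among the three groups compared at this nitrogen with the nitro-bearing core, only 2,6-dimethylphenyl stands apart, and the other two cannot be told apart on these numbers.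

The compounds shown leave open whether both methyl groups of the 2,6-dimethylphenyl pattern are needed, and whether other groups in that pattern, such as 2,6-diethylphenyl or 2,6-dichlorophenyl, would give a similar number. They also leave open whether the same step would appear on the core of compound 3, which lacks the nitro groups. Nothing measured here accounts for the step at this nitrogen.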